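The compounds below may be only part of what the source reports. "The series", "measured", "known", "first", "only" and "open" are said of these compounds alone.

Measured so far:

Compound 1, `NC(=O)CCc1ccc(NCc2cccc(Oc3ccccc3)c2)cc1` — 51.3 nM
Compound 2, `CN(C)C(=O)CCc1ccc(NCc2cccc(Oc3ccccc3)c2)cc1` — 174 nM
Compound 3, `Cc1nc(-c2ccc(C(F)(F)F)cc2)sc1CNc1ccc([C@H]2C[C@@H]2C(N)=O)cc1` — 4.47 nM

All three were tested in a functional assay on CHO cells for agonist activity at Free fatty acid receptor 1 (Homo sapiens); a lower number here means that less compound is needed, a higher number that more compound is needed for the effect. Compound 1 and compound 2 share one core and differ in a single spot: dimethylamino in place of amino on a carbonyl carbon. That change made a step of a 3.4-fold higher number from compound 1 to compound 2 (0.53 log units; beyond the scatter). Compound 3 sits on a different core; how the two cores differ is not broken down here, and the values simply show that compound 3 needs the least compound of the three, with compound 1 coming nearest.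

Compound 4, `Cc1nc(-c2ccc(C(F)(F)F)cc2)sc1CNc1ccc([C@H]2C[C@@H]2C(=O)N(C)C)cc1`, has not yet been measured. It is built from compound 3 by the same kind of change: dimethylamino in place of amino on a carbonyl carbon. The surroundings are not identical, since in compound 1 the carbonyl carbon sits on a saturated chain carbon, while in compound 3 it sits on a saturated ring carbon, so the two changes are the same kind rather than the same.

For compound 4 in this assay a step of a 3.4-fold higher number from compound 3 to compound 4 (0.53 log units; beyond the scatter) is expected, resting on the earlier step of a 3.4-fold higher number from compound 1 to compound 2 (0.53 log units; beyond the scatter). The estimate for compound 4 is therefore 15 nM, with a range from 6 nM to 40 nM.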

Compound 4, half-maximal effective concentration: 66.1 nM
Beside the measured number, compound 4's estimate is 4.4-fold (0.64 log units) below it, outside the stated range (above it).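

In this assay, putting dimethylamino in place of amino on the carbonyl carbon gives a 15-fold higher number from compound 3 to compound 4 (1.17 log units; beyond the scatter), so the number rises on this core as it did on the core of compound 1. The direction of the change therefore carries over in these two pairs, but its size does not: the same change on two cores in this assay, a 3.4-fold higher number (0.53 log units; beyond the scatter) from compound 1 to compound 2 and a 15-fold higher number (1.17 log units; beyond the scatter) from compound 3 to compound 4, 4.4-fold (0.64 log units) apart, beyond the scatter of two such steps This does not show what sets the size of the step, since the two cores differ in several places, and the carbonyl carbon sits on a saturated chain carbon in compound 1 but on a saturated ring carbon in compound 3, and two pairs cannot separate these differences.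

The compounds shown leave open how methylamino, with one methyl group on the amide nitrogen instead of two, would fall on either core. They also leave open whether a carboxylic acid in place of the amide would follow the same direction, and how large the step from amino to dimethylamino would be on a third core.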